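The source may hold more compounds than are shown below. What is called first, only, known or untested is meant among the compounds shown, and "the series" means these compounds.

Measured compounds:

Compound 1, `CCCc1cn(C/C=C(\C)CCC=C(C)C)nn1`, gives 4.5 in a physicochemical assay for lipophilicity, measured as octanol-water partition; a lower number here means a more polar compound, a higher number a more lipophilic compound.
Compound 2, `CC(C)=CCC/C(C)=C/Cn1cc(-c2ccccc2)nn1`, gives 4.91 in this assay.
Compound 3, `CCCc1cn(C/C=C(\C)CC/C=C(\C)CCC=C(C)C)nn1`, gives 6.5 in this assay.

Compound 3 carries the longest chain of the three and sits highest. Cutting that chain back gives compound 1, a change of hydrogen in place of 3-methylbut-2-en-1-yl on a saturated chain carbon bound to a double-bonded chain carbon, and the partition coefficient falls by a number 2.00 log units lower from compound 3 to compound 1 (beyond the scatter). Going from compound 1 to compound 2 swaps the group on the shared core, and the partition coefficient rises by a number 0.41 log units higher from compound 1 to compound 2 (beyond the scatter). Compound 2 thus stands second highest of the three; the difference between the cores of compound 2 and compound 3 is not broken down here.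

Compound 4, `CC(C)=CCn1cc(-c2ccccc2)nn1`, has not yet been measured in this assay. It is reached from compound 2 by hydrogen in place of 3-methylbut-2-en-1-yl on a saturated chain carbon bound to a double-bonded chain carbon. Among the compounds with values here, this is the same change, at the same kind of place, that turned compound 3 into compound 1, so the step from compound 2 to compound 4 is expected to be about as large, a number 2.01 log units lower from compound 2 to compound 4 (beyond the scatter), a figure that rests on the one earlier example, a number 2.00 log units lower from compound 3 to compound 1 (beyond the scatter). Within the data shown here, with only a single earlier instance to lean on, the range is kept wide. Compound 4 is therefore estimated at 2.9 in this assay, most likely between 2.3 and 3.5.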

Compound 4, partition coefficient: 2.82
For compound 4 the middle estimate is 0.08 log units above the measured one, within the range that was stated.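

Removing the 3-methylbut-2-en-1-yl group lowers the partition coefficient in this assay by a similar amount on two versions of the core: the new step, a number 2.09 log units lower from compound 2 to compound 4 (beyond the scatter), stands close in printed size to the earlier one, a number 2.00 log units lower from compound 3 to compound 1 (beyond the scatter), although one pair carries phenyl on the shared core and the other carries propyl. Within these two pairs, then, the size of the step stays nearly the same when phenyl takes the place of propyl, and neither pair goes against this, so a value measured on one core served as a useful guide on the other. This does not establish a general rule, since two pairs involving one chain group at one kind of place cannot show how the step behaves elsewhere, and no measurement shown explains its size.

As far as these compounds go, it remains open whether the step keeps this size when the shared core carries an amine or a carboxylic acid instead of phenyl or propyl. The compounds shown also leave open what happens when the same group is removed from a longer chain than the one in compound 3.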